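Acetamido in place of acetoxy: notes on the series

The compounds below may be only part of what the source reports. "The series", "measured", "known", "first", "only" and "open" are said of these compounds alone.

Measured in a functional assay on Hs-578T cells (Homo sapiens) for antiproliferative activity; a higher number here means a weaker inhibitor of growth, a lower number a stronger inhibitor of growth:
- compound 1 `COCCCCCCCCCCCCCCC/C=C1\CC(CO)(COC(=O)C(C)(C)C)OC1=O`: 5.45 ug/mL
- compound 2 `CC(=O)OCCCCCCCCCCCCCCC/C=C1\CC(CO)(COC(=O)C(C)(C)C)OC1=O`: > 10 ug/mL, a limit

Compound 2 has no number in this assay, only a limit. It sits at the limit of > 10 ug/mL in this assay, at which 1 of the 2 values shown sits. The change to compound 3 `CC(=O)NCCCCCCCCCCCCCCC/C=C1\CC(CO)(COC(=O)C(C)(C)C)OC1=O` is acetamido in place of acetoxy on a saturated chain carbon, ten or more bonds along the chain from a double-bonded chain carbon.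

Going by the values given here, the one measured step is an at least 1.8-fold higher number from compound 1 to compound 2 (0.26 log units; that floor lies within the scatter), with acetyl in place of methyl on an oxygen on a saturated carbon. That step is a different exchange, and its size is known only as a floor. Among the compounds with values here, no measured step has acetamido in place of acetoxy, so the data give no direction for this change. No step beyond the scatter is expected in this assay. The expectation rests on compound 2 at > 10 ug/mL as a limit, with the reading of compound 1 at 5.45 ug/mL taken as a guide to the lower side of the range.

The estimated step is a number no higher from compound 2 to compound 3 (the limit leaves the size open). A report of a limit alone is about as likely as a number. Compound 3 is expected at 10 ug/mL, with an estimated range of 4 ug/mL to 25 ug/mL.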

Compound 3, concentration for 50% growth inhibition: > 10 ug/mL
Compound 3 ended at the assay's limit (the forecaster's own chance of this, stated with the estimate: 50%); the middle value lies on the limit itself.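

In this assay, compound 3 gives > 10 ug/mL, which is a limit and not a number. Acetamido in place of methoxy on the saturated chain carbon gives an at least 1.8-fold higher number from compound 1 to compound 3 (0.26 log units; that floor lies within the scatter), so this exchange, like the acetyl one before it, yields only a floor and no step shown beyond the scatter. The new information is that swapping acetoxy for acetamido, which adds a hydrogen-bond donor, does not bring a readable value back into this assay; the step between those two compounds cannot be read, and the series now gathers at its limit: the limit of > 10 ug/mL in this assay, at which 2 of the 3 values shown sit.

As far as these compounds go, whether acetamido and acetoxy differ at all in this place therefore stays open, as does how far either lies from compound 1, which gives 5.45 ug/mL. Also open, from the compounds shown here alone, is whether a hydroxyl, an amine or a carboxylic acid in the same place on the chain, or a shorter chain bearing methoxy, would give a readable value in this assay.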